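A few compounds are considered here, and "the series" means these few. Any claim that something is new, unique, unknown or untested is made for them only; others in the source may bear on it.

Compound 1 `COC(=O)c1nc(-c2ccc[nH]2)n(-c2ccc(F)cc2)n1`: 9580 nM
Compound 2 `CCOC(=O)c1nc(-c2ccc[nH]2)n(-c2ccc(C(F)(F)F)cc2)n1`: 76400 nM

In a functional assay on NPC-TW01 cells (Homo sapiens) for inhibition, read by MTT assay, with a stated time of 72 h (a lower number here means a stronger inhibitor of growth, a higher number a weaker inhibitor of growth), compound 2 gives 76400 nM, the higher of the two numbers, and compound 1 gives 9580 nM, a gap well beyond the scatter. Compound 3 `CCOC(=O)c1nc(-c2ccc[nH]2)n(-c2ccc(F)cc2)n1` is not yet measured; it differs from compound 2 by fluoro in place of trifluoromethyl on an aromatic carbon. Compound 3 is expected to move toward compound 1, a step of a 5.1-fold lower number from compound 2 to compound 3 (0.71 log units; beyond the scatter), because compound 1, which also carries fluoro rather than trifluoromethyl, gives 9580 nM. For compound 3 the estimate is 15000 nM, within 5000 nM to 50000 nM.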

Compound 3, concentration for 50% growth inhibition: 64300 nM
Compound 3: the middle estimate sits 4.3-fold (0.63 log units) below what was measured; the whole stated range lies below it.
By their numbers in this assay, from the lowest: compound 1; then compounds 3 and 2 (each within the scatter of the next).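

In this assay, replacing trifluoromethyl with fluoro on the aromatic carbon gives a 1.2-fold lower number from compound 2 to compound 3 (0.07 log units; within the scatter) with the ethyl ester in place, so this swap makes no clear difference here. The ester does matter: with fluoro held constant, methyl in place of hydrogen on the chain carbon bound to oxygen gives a 6.7-fold higher number from compound 1 to compound 3 (0.83 log units; beyond the scatter) and thus accounts for the loss between these two compounds. No measured information explains either result.

Going by these compounds, whether the aromatic swap would also make no difference in a methyl ester remains open. So does the effect of a carboxylic acid, an amide or a longer chain at the ester.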